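Swapping an acid-bearing chain for a chlorothiazole amide

The source may hold more compounds than are shown below. What is called first, only, known or untested is meant among the compounds shown, and "the series" means these compounds.

Compound 1, with structure `O=C(O)/C=C/C(=O)Nc1cccc(-c2nc3ccccc3s2)c1`, sits at the edge of what an ADME assay on HEK293 cells (Homo sapiens) for inhibition, with a stated time of 72 h (on this read-out higher numbers stand for an effect only at larger amounts of compound and lower numbers for an effect already at smaller amounts), can report. In this assay compound 1 gives > 25000 nM, which is a limit of the assay rather than a number. Compound 3, `O=C(Nc1cccc(-c2nc3ccccc3s2)c1)c1cccnc1Cl`, also gives > 25000 nM, again a limit. Compound 2, `O=C(CCl)Nc1cccc(-c2nc3ccccc3s2)c1`, gives 10000 nM, a real number. Two of the three values therefore stand at a limit, as noted in the limit of > 25000 nM in this assay, at which 2 of the 3 values shown sit.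

The unmeasured compound 4, `O=C(Nc1cccc(-c2nc3ccccc3s2)c1)c1cnc(Cl)s1`, differs from compound 1 in one place: 2-chloro-1,3-thiazol-5-yl in place of 2-carboxyethenyl on a carbonyl carbon.

Within the data shown here, two measured steps bear on this change. The step that the two limits leave unreadable from compound 1 to compound 3 replaces the same chain with another chlorinated aromatic ring, and its size cannot be read because both ends are limits. The step of an at least 2.5-fold higher number from compound 2 to compound 3 (0.39 log units; beyond the scatter) shows that moving from chloromethyl to a chlorinated aromatic ring raises the number. Among the measured compounds shown here, since compound 3 carries a ring of the same kind as the one entering compound 4, compound 4 is expected to stay near the limit, with an expected step of a number no higher from compound 1 to compound 4 (the limit leaves the size open). The estimate for compound 4 is 25000 nM, within 8000 nM to 70000 nM.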

Compound 4, half-maximal effective concentration: > 25000 nM
Compound 4: a limit, no number (the forecaster's own chance of this, stated with the estimate: 70%); the middle value sits exactly at the limit.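

In this assay compound 4 gives > 25000 nM, a limit and not a number. The five-membered 2-chloro-1,3-thiazol-5-yl ring on this carbonyl carbon now gives a second readable comparison with the chloromethyl compound, an at least 2.5-fold higher number from compound 2 to compound 4 (0.39 log units; beyond the scatter), so the six-membered 2-chloropyridin-3-yl ring of compound 3 is not alone in giving a higher number than chloromethyl. The steps among compound 1, compound 3 and compound 4 join limit to limit and cannot be read, and chloromethyl remains the only group at this place with a real number: the limit of > 25000 nM in this assay, at which 3 of the 4 values shown sit.

As far as these compounds go, how compound 1, compound 3 and compound 4 rank against each other stays open. Also open is whether the chlorine of compound 2 matters, since a plain methyl or a bromomethyl group on the same carbonyl carbon is not among the compounds shown.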